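Swapping phenyl for pyridin-2-yl on a cyclohexyl compound

The compounds below may be only part of what the source reports. "The series", "measured", "known", "first", "only" and "open" are said of these compounds alone.

- Compound 1 `CC(=O)c1ccc2[nH]c(-c3ccccc3)nc2c1`: > 100000 nM (a limit of the assay)
- Compound 2 `CC(=O)c1ccc2c(c1)nc(-c1ccccc1)n2C1CCCCC1`: 80000 nM

Among the measured compounds shown here, in an ADME assay on Vero cells (Chlorocebus sabaeus) for cytotoxicity, read by MTT assay, with a stated time of 96 h (on this read-out lower numbers stand for higher toxicity in this test and higher numbers for lower toxicity in this test), compound 2 gives 80000 nM, the only true number so far. Compound 1 reads > 100000 nM, which is a limit. The evidence on the measured step is thin, with the limit of > 100000 nM in this assay, at which 1 of the 2 values shown sits. That single step, an at least 1.2-fold lower number from compound 1 to compound 2 (0.09 log units; that floor lies within the scatter), put cyclohexyl in place of hydrogen on an aromatic nitrogen.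

Compound 3 `CC(=O)c1ccc2c(c1)nc(-c1ccccn1)n2C1CCCCC1` changes another place, with pyridin-2-yl in place of phenyl on an aromatic carbon. For the measured compounds named here, no measured step covers this change, so nothing beyond the scatter is expected in this assay. The expected step is a 1.1-fold lower number from compound 2 to compound 3 (0.03 log units; within the scatter). Compound 3 is estimated at 75000 nM, within an expected range of 40000 nM to 100000 nM.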

Compound 3, half-maximal cytotoxic concentration: > 90000 nM
Compound 3 was reported as a limit; the forecaster's own chance of this, stated with the estimate: 35%; middle value at least 1.2-fold (0.07 log units) away from the limit.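

Pyridin-2-yl in place of phenyl on this aromatic carbon gives an at least 1.1-fold higher number from compound 2 to compound 3 (0.05 log units; that floor lies within the scatter) in this assay. Among the compounds shown here, this is the first reading at this place, and with a ring nitrogen entering, it shows no sign of higher toxicity in this test. The value of compound 3 is a limit of the assay, so the step can be read only as a floor: the limit of > 90000 nM in this assay, at which 1 of the 3 values shown sits.

The compounds shown leave open how far the true number of compound 3 lies from that of compound 2. They also leave open whether an amine or a carboxylic acid in place of the pyridin-2-yl would bring the number down.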